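The source may report more compounds than this note shows. Statements on the series, on what has been measured and on what is new or still open speak of the compounds shown alone.

Measured so far in an assay on HEK293 cells for displacement of a labelled ligand from D(3) dopamine receptor (Rattus norvegicus), with a stated time of 1 h; a lower number here means a stronger inhibitor, a higher number a weaker inhibitor:
compound 1 `CCCN(CCCCCc1ccc(O)c(O)c1)C1CCc2nc(N)sc2C1` — 2.59 nM
compound 2 `CCCN(CCCc1ccc(O)c(O)c1)C1CCc2nc(N)sc2C1` — 11.9 nM
compound 3 `CCCN(CCCCCc1ccc(O)c(OC)c1)C1CCc2nc(N)sc2C1` — 3.62 nM

Compound 1 and compound 3 differ by a single change: methyl in place of hydrogen on an oxygen on an aromatic ring. In this assay this change gave a 1.4-fold higher number from compound 1 to compound 3 (0.15 log units; within the scatter), so the two compounds cannot be told apart by this assay. Compound 2 has the highest number of the three, and the difference between its core and the core of compound 1 is not broken down here. Compound 4 `CCCN(CCCc1ccc(O)c(OC)c1)C1CCc2nc(N)sc2C1` is not yet measured; it relates to compound 2 by the same change, (methyl in place of hydrogen on an oxygen on an aromatic ring). Because the first step was a 1.4-fold higher number from compound 1 to compound 3 (0.15 log units; within the scatter), the expected step from compound 2 to compound 4 is a 1.3-fold higher number from compound 2 to compound 4 (0.10 log units; within the scatter). Compound 4 is therefore estimated to give 15 nM in this assay, with a likely range from 7 nM to 35 nM.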

Compound 4, inhibition constant: 15.8 nM
Beside the measured number, compound 4's estimate is 1.1-fold (0.02 log units) below it; low and high end bracket the measured number.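

In this assay, putting methoxy in place of hydroxy gave a 1.3-fold higher number from compound 2 to compound 4 (0.12 log units; within the scatter), so compound 2 and compound 4 cannot be told apart. The change gave matching results on both cores: the same change on two cores in this assay, a 1.4-fold higher number (0.15 log units; within the scatter) from compound 1 to compound 3 and a 1.3-fold higher number (0.12 log units; within the scatter) from compound 2 to compound 4, 1.1-fold (0.02 log units) apart, within the scatter of two such steps

Across these two pairs, then, the swap of hydroxy to methoxy carries over from one core to the other with no step large enough to stand out from the scatter, but two pairs cannot show that this would hold on any other core, and they do not explain the result. The compounds shown leave open what a larger group on that oxygen, such as ethoxy or benzyloxy, would do to the number in this assay. An amine in place of the hydroxy is also left open.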